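A Methoxycarbonyl Group Added to Compound 2

This account rests on a few compounds, and the source may have more. Where it says the series, first, only, none or still open, it means among the compounds named here.

Among the compounds with values here, in a functional assay on SK-OV-3 cells (Homo sapiens) for inhibition, read by CCK-8 assay, with a stated time of 70 h (a lower number here means a stronger inhibitor, a higher number a weaker inhibitor), compound 1 (`OCCOCCOCCOc1ccc(OCc2ccccc2)cc1`) gives 59400 nM, and compound 2 (`c1ccc(COc2ccc(OCCOCCNC3CCCCC3)cc2)cc1`) gives 7370 nM, the lowest number measured so far. Compound 3 (`c1ccc(COc2ccc(OCCOCCNc3ccccc3)cc2)cc1`) reaches only a limit of the assay, > 100000 nM.

Compound 4 (`COC(=O)c1ccc(COc2ccc(OCCOCCNC3CCCCC3)cc2)cc1`) differs from compound 2 by methoxycarbonyl in place of hydrogen on an aromatic carbon.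

Two measured steps show how far the numbers can move. Cyclohexylamino in place of 2-hydroxyethoxy gives an 8.1-fold lower number from compound 1 to compound 2 (0.91 log units; beyond the scatter), and phenyl in place of cyclohexyl on the amine nitrogen gives an at least 13-fold higher number from compound 2 to compound 3 (1.13 log units; beyond the scatter). Both changes lie on the chain or its amine nitrogen, so neither measures a change on the aromatic carbon altered in compound 4. No direction can therefore be drawn from them, and the expectation stays close to compound 2 at 7370 nM, with a wide range.

The estimated change is a 1.2-fold higher number from compound 2 to compound 4 (0.09 log units; within the scatter), and no step beyond the scatter is expected. Compound 4 is expected at about 9000 nM, with an estimated range from 2500 nM to 35000 nM.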

Compound 4, half-maximal inhibitory concentration: 6220 nM
Estimate against measurement, compound 4: 1.4-fold (0.16 log units) above, within the range that was stated.
By their numbers in this assay, from the lowest: compounds 4 and 2 (each within the scatter of the next); then compound 1. At a limit, above all of these: compound 3.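

Replacing phenyl with 4-(methoxycarbonyl)phenyl gives, in this assay, a 1.2-fold lower number from compound 2 to compound 4 (0.07 log units; within the scatter), the first step shown on this aromatic carbon, para to a large group. The two steps beyond the scatter shown earlier both lay on the chain or its amine nitrogen, whereas here a group of 4 heavy atoms, with 2 hydrogen-bond acceptors, enters without a step beyond the scatter, so the numbers of compound 2 and compound 4 cannot be told apart. Nothing among the measurements shown bears on why this aromatic carbon tolerates the change.

This is one group at one position, so the compounds shown leave open whether a carboxylic acid, an amine or a longer ester on the same carbon would also stay within the scatter. They also leave open whether methoxycarbonyl at the other carbons of this ring would do the same.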